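Bromophenyl for Methoxyphenyl on a Thiophene Core

The source may hold more compounds than are shown below. What is called first, only, known or untested is meant among the compounds shown, and "the series" means these compounds.

Measured compounds:
Compound 1, `COc1ccc(-c2sc(C(=O)O)cc2-c2cc(OC)c(OC)c(OC)c2)cc1`, 7800 nM.
Compound 2, `COc1cc(-c2cc(C(=O)O)sc2-c2cccc(Br)c2)cc(OC)c1OC`, 93400 nM.
Compound 3, `COc1ccc(-c2sccc2-c2cc(OC)c(OC)c(OC)c2)cc1`, 5470 nM.

In a functional assay on SGC-7901 cells (Homo sapiens) for antiproliferative activity, read by MTT assay, with a stated time of 72 h (on this read-out higher numbers stand for weaker inhibition and lower numbers for stronger inhibition), compound 1 gives 7800 nM. The change 3-bromophenyl in place of 4-methoxyphenyl on an aromatic carbon produced a 12-fold higher number from compound 1 to compound 2 (1.08 log units; beyond the scatter). Compound 3 differs from compound 1 by hydrogen in place of carboxy on an aromatic carbon, and that step is a 1.4-fold lower number from compound 1 to compound 3 (0.15 log units; within the scatter), so the two cores cannot be told apart on this read-out.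

Compound 4, `COc1cc(-c2ccsc2-c2cccc(Br)c2)cc(OC)c1OC`, is not yet measured. It differs from compound 3 by 3-bromophenyl in place of 4-methoxyphenyl on an aromatic carbon. Among the compounds with values here, this is the same kind of change as the one from compound 1 to compound 2, but not the same: in the earlier pair the place was also two ring bonds from the ring atom that bears a carboxy group (3 heavy atoms), whereas in compound 3 that ring atom carries hydrogen. Because the earlier step was a 12-fold higher number from compound 1 to compound 2 (1.08 log units; beyond the scatter), the expected step here is a 9.1-fold higher number from compound 3 to compound 4 (0.96 log units; beyond the scatter), a step of similar size. The estimate for compound 4 is therefore 50000 nM, expected to lie between 15000 nM and 150000 nM.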

Compound 4, half-maximal inhibitory concentration: 46100 nM
The estimate for compound 4 lay 1.1-fold (0.04 log units) above the measured number; low and high end bracket the measured number.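

In this assay, 3-bromophenyl in place of 4-methoxyphenyl gave an 8.4-fold higher number from compound 3 to compound 4 (0.93 log units; beyond the scatter) on the core without the carboxy group, and this agrees with the earlier step on the core that carries it: the same change on two cores in this assay, a 12-fold higher number (1.08 log units; beyond the scatter) from compound 1 to compound 2 and an 8.4-fold higher number (0.93 log units; beyond the scatter) from compound 3 to compound 4, 1.4-fold (0.15 log units) apart, within the scatter of two such steps
Hydrogen in place of carboxy on the 3-bromophenyl compounds gave a 2.0-fold lower number from compound 2 to compound 4 (0.31 log units; beyond the scatter), which also agrees with the same change on the 4-methoxyphenyl compounds: the same change on two cores in this assay, a 1.4-fold lower number (0.15 log units; within the scatter) from compound 1 to compound 3 and a 2.0-fold lower number (0.31 log units; beyond the scatter) from compound 2 to compound 4, 1.4-fold (0.15 log units) apart, within the scatter of two such steps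
This shows the change carrying over between these two cores in this one cell read-out, but two pairs do not show that it would hold on other cores or in other cells, and they do not explain why the numbers rise.

The compounds shown do not separate the loss of the methoxy group from the arrival of the bromine, for the two change together in both pairs. They also leave open how a plain phenyl ring, an amine or a longer alkoxy chain would read in that place, and how an ester or an amide would compare with the carboxy group.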